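The compounds below may be only part of what the source reports. "The series", "measured", "known", "first", "only" and "open" are said of these compounds alone.

Measured compounds and their values in an assay on HEK293 cells for displacement of a labelled ligand from NPC1-like intracellular cholesterol transporter 1 (Homo sapiens); a higher number here means a weaker inhibitor, a lower number a stronger inhibitor:
compound 1 `CC(C)(C)c1ccc(C(=O)N2CCC3(CC2)C(=O)N(CC(=O)NCCO)CN3c2ccccc2)cc1` gives 1000 nM
compound 2 `CC(C)(C)c1ccc(C(=O)N2CCC3(CC2)C(=O)N(CC(=O)N2CCCCC2CCO)CN3c2ccccc2)cc1` gives 6100 nM
compound 3 `CC(C)(C)c1ccc(C(=O)N2CCC3(CC2)C(=O)N(CC(=O)N2CCCC(CO)C2)CN3c2ccccc2)cc1` gives 8200 nM

Compound 3 gives the highest number of the three in this assay, but its nearest neighbour is compound 2, and a 1.3-fold higher number from compound 2 to compound 3 (0.13 log units; within the scatter) lies within the scatter, so the two cannot be ranked against each other. The gap to compound 1 is clear: an 8.2-fold higher number from compound 1 to compound 3 (0.91 log units; beyond the scatter). Compound 2 shows the same sort of separation from compound 1, a 6.1-fold higher number from compound 1 to compound 2 (0.79 log units; beyond the scatter).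

Compound 4 `CC(C)(C)c1ccc(C(=O)N2CCC3(CC2)C(=O)N(CC(=O)N2CCCCC2CO)CN3c2ccccc2)cc1` has not yet been measured. It differs from compound 3 by 2-(hydroxymethyl)piperidin-1-yl in place of 3-(hydroxymethyl)piperidin-1-yl on a carbonyl carbon. Among the compounds with values here, the only measured step that bears on this change is the one between the two piperidine amides, a 1.3-fold higher number from compound 2 to compound 3 (0.13 log units; within the scatter), where shifting the hydroxyalkyl group around the ring and changing its length made no difference beyond the scatter. Both of those compounds sit well away from compound 1, which carries the open-chain (2-hydroxyethyl)amino group. A move of the hydroxymethyl group from one ring position to another within the same closed ring is therefore expected to change little. The step of a 1.2-fold lower number from compound 3 to compound 4 (0.07 log units; within the scatter) is expected to stay within the scatter. Compound 4 is expected to give about 7000 nM in this assay, within a range from 2500 nM to 20000 nM.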

Compound 4, half-maximal inhibitory concentration: 11800 nM
The estimate for compound 4 lay 1.7-fold (0.23 log units) below the measured number, within the range that was stated.
By their numbers in this assay, from the lowest: compound 1; then compounds 2, 3 and 4 (each within the scatter of the next).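

In this assay, moving the hydroxymethyl group, with 2-(hydroxymethyl)piperidin-1-yl taking the place of 3-(hydroxymethyl)piperidin-1-yl on the carbonyl carbon, gives a 1.4-fold higher number from compound 3 to compound 4 (0.16 log units; within the scatter), and replacing 2-(2-hydroxyethyl)piperidin-1-yl by 2-(hydroxymethyl)piperidin-1-yl gives a 1.9-fold higher number from compound 2 to compound 4 (0.29 log units; within the scatter), so neither the attachment point on the ring nor the chain length separates these piperidine amides in the cases shown. The contrast with the open-chain (2-hydroxyethyl)amino amide now holds for a third ring amide, at a 12-fold higher number from compound 1 to compound 4 (1.07 log units; beyond the scatter), and among the compounds shown none of the piperidine amides goes against it. No measurement here accounts for this contrast between the open-chain amide and the ring amides.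

The compounds shown leave open whether the hydroxy group contributes at all in the ring amides, a question that a plain piperidin-1-yl amide would address. They also leave open whether the ring itself or the loss of the amide hydrogen sets compound 1 apart, which a 4-(hydroxymethyl)piperidin-1-yl group or an open-chain N-methyl-(2-hydroxyethyl)amino group could help to settle.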